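Methoxy for Chloro on the Other Aryl Ring

The source may report more compounds than this note shows. Statements on the series, on what has been measured and on what is new or still open speak of the compounds shown alone.

Compound 1, `O=C(/C=C\Nc1ccc(F)cc1)c1cn(-c2ccccc2)nc1-c1ccc(Cl)cc1`: 17900 nM
Compound 2, `O=C(/C=C\Nc1ccc(Cl)cc1)c1cn(-c2ccccc2)nc1-c1ccc(Cl)cc1`: 13100 nM
Compound 3, `COc1ccc(N/C=C\C(=O)c2cn(-c3ccccc3)nc2-c2ccc(Cl)cc2)cc1`: 6890 nM

Of the compounds shown here, three sharing one core have been measured in a functional assay on U-87MG ATCC cells (Homo sapiens) for antiproliferative activity, read by MTT assay, with a stated time of 48 h; a higher number here means a weaker inhibitor, a lower number a stronger inhibitor. Compound 1 gives 17900 nM and stands at the highest number of the three. Compound 2 differs from compound 1 by fluoro in place of chloro on an aromatic carbon. Compound 2 gives 13100 nM; the step of a 1.4-fold lower number from compound 1 to compound 2 (0.14 log units; within the scatter) is within the scatter. Compound 3 gives 6890 nM; the step of a 2.6-fold lower number from compound 1 to compound 3 (0.41 log units; beyond the scatter) is modest but beyond the scatter, while the step of a 1.9-fold lower number from compound 2 to compound 3 (0.28 log units; within the scatter) is within it.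

Compound 4, `COc1ccc(-c2nn(-c3ccccc3)cc2C(=O)/C=C\Nc2ccc(F)cc2)cc1`, has not yet been measured. It differs from compound 1 by methoxy in place of chloro on an aromatic carbon. The change from compound 2 to compound 3 is methoxy in place of chloro on an aromatic carbon. Both are the same kind of change, yet not the same: cut one bond further out, the change from compound 2 to compound 3 also reads (4-chlorophenyl)amino to (4-methoxyphenyl)amino, a reading that the change from compound 1 to compound 4 does not carry, so the two changes fall on different rings of the shared core.

Because the measured step of a 1.9-fold lower number from compound 2 to compound 3 (0.28 log units; within the scatter) was within the scatter, compound 4 is expected to show a step of about a 1.5-fold lower number from compound 1 to compound 4 (0.17 log units; within the scatter) in this assay. Compound 4 is therefore estimated at 12000 nM, with a likely range from 5000 nM to 35000 nM.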

Compound 4, half-maximal inhibitory concentration: 8910 nM
Compound 4: middle estimate off by 1.3-fold (0.13 log units), on the high side; the measured number falls inside the stated range.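

In this assay, putting 4-methoxyphenyl in place of 4-chlorophenyl on the shared core gives a 2.0-fold lower number from compound 1 to compound 4 (0.30 log units; within the scatter). This is the same chloro-to-methoxy exchange that had been seen on the other aryl ring, where it read (4-chlorophenyl)amino to (4-methoxyphenyl)amino, and the two steps agree in size: the same change on two cores in this assay, a 1.9-fold lower number (0.28 log units; within the scatter) from compound 2 to compound 3 and a 2.0-fold lower number (0.30 log units; within the scatter) from compound 1 to compound 4, 1.1-fold (0.02 log units) apart, within the scatter of two such steps This agreement shows that, in these two pairs, the exchange gave a step of similar size on either ring, but it does not show that methoxy truly outperforms chloro on either ring, since neither step clears the scatter, and two pairs cannot establish a rule for the series.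

The compounds shown leave open whether methoxy on both aryl rings at once would give a step beyond the scatter, which would be the clearer test of whether the two small steps are real and add together. They also leave open how other groups in the same place, such as a hydroxyl, an amine or a longer chain like ethoxy, would compare, and whether the exchange would carry over to a core in which the unsubstituted phenyl is replaced.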